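Replacing the chloro in compound 1 with a piperazinyl group

The source may hold more compounds than are shown below. What is called first, only, known or untested is meant among the compounds shown, and "the series" means these compounds.

Measured compounds:
compound 1 `Cn1c(-c2ccc(NC(=O)CCl)cc2)nc(-c2ccccc2)c1-c1ccccc1`, 15.1%
compound 2 `Cn1c(-c2ccc(NC(=O)CSc3nc4ccccc4o3)cc2)nc(-c2ccccc2)c1-c1ccccc1`, 44.9%
compound 3 `Cn1ccnc1SCC(=O)Nc1ccc(-c2nc(-c3ccccc3)c(-c3ccccc3)n2C)cc1`, 30.7%

In a functional assay on HT-29 cells (Homo sapiens) for cytotoxicity, read by MTT assay, with a stated time of 24 h, tested at 6.4 ug/mL (on this read-out lower numbers stand for a weaker effect and higher numbers for a stronger effect at the one concentration tested), compound 1 gives the lowest of the three numbers. Its nearest neighbour is compound 3, and the gap is a number 15.6 percentage points higher from compound 1 to compound 3 (beyond the scatter); compound 2 lies furthest away, with a number 29.8 percentage points higher from compound 1 to compound 2 (beyond the scatter). Both of these steps exchange the chloro for a sulfur-linked group, and in both cases the number rises modestly, beyond the scatter. Between the two sulfur-linked compounds the step is a number 14.2 percentage points lower from compound 2 to compound 3 (beyond the scatter).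

Compound 4 `CN(C)/C=C/N1CCN(CC(=O)Nc2ccc(-c3nc(-c4ccccc4)c(-c4ccccc4)n3C)cc2)CC1` is not yet measured. It differs from compound 1 by 4-(2-(dimethylamino)ethenyl)piperazin-1-yl in place of chloro on a saturated chain carbon bound to a carbonyl carbon. Among the measured compounds shown here, no measured step carries this same group, so the two steps from compound 1 only show that exchanging the chloro at this position has so far raised the number modestly. A modest rise is therefore expected here too, though with wide uncertainty because the entering group is unlike either sulfur-linked group.

Compound 4 is expected to give 30%, within a range from 12% to 50%. The step expected is a number 14.9 percentage points higher from compound 1 to compound 4 (beyond the scatter).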

Compound 4, a percentage reported as activity, at one concentration (the size of the read-out at that concentration, not a potency): 12.2%
The estimate for compound 4 lay 17.8 percentage points above the measured number; the range from low to high includes it.
By their numbers in this assay, from the lowest: compounds 4 and 1 (each within the scatter of the next); then compound 3; then compound 2.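

In this assay the exchange of chloro for 4-(2-(dimethylamino)ethenyl)piperazin-1-yl gives a number 2.9 percentage points lower from compound 1 to compound 4 (within the scatter) and so shows that replacing the chloro on this saturated chain carbon bound to a carbonyl carbon does not by itself bring a rise. The rises seen so far belong only to the two sulfur-linked groups, and the new group stands apart from both, with a number 18.5 percentage points lower from compound 3 to compound 4 (beyond the scatter) and with a number 32.7 percentage points lower from compound 2 to compound 4 (beyond the scatter) as well. Nothing measured here explains these gaps.

Still open, going by these compounds, is whether the piperazine ring or its ethenyl-linked dimethylamino end shapes the number, a question that a plain piperazin-1-yl or a morpholin-4-yl group on the same carbon would address. Also open, on these data alone, is whether the sulfur link matters, which a (1,3-benzoxazol-2-yl)oxy group in its place would test.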